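Trimming a biphenyl anilide down to a single phenyl

The source may report more compounds than this note shows. Statements on the series, on what has been measured and on what is new or still open speak of the compounds shown alone.

Three dichloroacetamides have been tested in a functional assay on NCI-H460 cells (Homo sapiens) for cytotoxicity, read by MTT assay, with a stated time of 68 h; a higher number here means a weaker inhibitor, a lower number a stronger inhibitor. Compound 1 `CSc1cccc(-c2cc(NC(=O)C(Cl)Cl)cc(-c3cccc(SC)c3)c2)c1` carries two methylthio-bearing aryl groups on the core that holds the amide. Compound 1 reaches only the limit of the assay, > 30000 nM. Compound 3 `COc1cccc(-c2cc(NC(=O)C(Cl)Cl)cc(-c3cccc(OC)c3)c2)c1` carries two methoxy-bearing aryl groups instead. Compound 3 likewise reaches only the limit, > 30000 nM. For the measured compounds named here, compound 2 `O=C(Nc1cccc(-c2ccc(-c3ccccc3)cc2)c1)C(Cl)Cl` is the sole compound with a number in this assay, where compound 2 gives 10900 nM. The other two readings are limits rather than numbers, as the limit of > 30000 nM in this assay, at which 2 of the 3 values shown sit, shows.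

Compound 4 `O=C(Nc1cccc(-c2ccccc2)c1)C(Cl)Cl` has not yet been tested. It differs from compound 2 in one place: hydrogen in place of phenyl on an aromatic carbon. Going by the values given here, no measured pair here changes a structure in a single place, so no measured step offers a direct guide; what the three values show is that the two larger compounds, compound 1 and compound 3, sit at the limit while compound 2 gives a number. Compound 4 is smaller still, and its strength in this assay is expected to fall rather than rise. The step expected is a 2.3-fold higher number from compound 2 to compound 4 (0.36 log units; beyond the scatter), a loss that may well push the reading past the limit. For compound 4 the estimate is 25000 nM, with a range from 8000 nM to 60000 nM.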

Compound 4, half-maximal inhibitory concentration: 20200 nM
Beside the measured number, compound 4's estimate is 1.2-fold (0.09 log units) above it; the range from low to high includes it.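

For the compounds shown here, this is the first step in the set between two compounds that differ in one place. In this assay, hydrogen in place of phenyl on an aromatic carbon, para to a large group, gives a 1.9-fold higher number from compound 2 to compound 4 (0.27 log units; within the scatter). The two readings therefore cannot be told apart, so at this position the phenyl makes no difference that this assay can resolve, and both compounds give real numbers that can be compared, which is not true of every compound here: the limit of > 30000 nM in this assay, at which 2 of the 4 values shown sit.

The compounds shown leave open how other groups on this same aromatic carbon would read, such as an amine or a carboxylic acid, for only phenyl and hydrogen appear there. What sets compound 1 and compound 3 apart from the other two also stays unresolved, for each differs from them in more than one place and no single change can be picked out.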